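Two Stereocentres Inverted, Cytotoxicity Expected to Stay Weak

The source may report more compounds than this note shows. Statements on the series, on what has been measured and on what is new or still open speak of the compounds shown alone.

Of the compounds shown here, two have so far been tested in a functional assay on A549 cells (Homo sapiens) for cytotoxicity, read by MTT assay; on this read-out lower numbers stand for stronger inhibition and higher numbers for weaker inhibition. Compound 1, `CC(=O)C1=C[C@@H]2[C@H](C(C)C)CC[C@@H](C)[C@]2(O)C1`, is reported only as a limit of the assay: in this assay compound 1 gives > 10 ug/mL. Compound 2, `CC(=O)[C@H]1C[C@]2(O)[C@@H]([C@@H]1O)[C@H](C(C)C)CC[C@H]2C`, is likewise reported as a limit rather than a number: in this assay compound 2 gives > 10 ug/mL. As noted in the limit of > 10 ug/mL in this assay, at which 2 of the 2 values shown sit, every value shown so far sits at that same limit, so compound 2 cannot be placed above or below compound 1 on the numbers; it simply stands where all measured compounds stand.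

Compound 3, `CC(=O)[C@@H]1C[C@]2(O)[C@@H]([C@H]1O)[C@H](C(C)C)CC[C@H]2C`, is the next compound to be measured. The change from compound 2 to compound 3 is the two compounds have the same atoms and bonds and differ only in configuration as drawn: 2 of 6 stereo elements differ; a stereocentre at a saturated ring carbon is drawn S in compound 2 and R in compound 3; a stereocentre at a saturated ring carbon is drawn S in compound 2 and R in compound 3. Among the measured compounds shown here, no step between two measured compounds is available to show how such a change in configuration moves this read-out. The step from compound 2 to compound 3 is expected to be a step that the limit leaves unreadable from compound 2 to compound 3, which means no movement beyond the usual scatter. Compound 3 is therefore estimated at 15 ug/mL in this assay, with a range from 5 ug/mL to 40 ug/mL, and most likely it will again be reported only as a limit.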

Compound 3, half-maximal inhibitory concentration: > 10 ug/mL
Compound 3: only a limit was reported; the forecaster's own chance of this, stated with the estimate: 75%; the middle value is on the limit's open side.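

In this assay compound 3 gives > 10 ug/mL, which is a limit and not a number. Compound 2 is also reported only as a limit, so no step can be read between compound 2 and compound 3. Compounds 1, 2 and 3 leave open how strongly each acts and whether configuration moves this read-out at all, with every value resting on: the limit of > 10 ug/mL in this assay, at which 3 of the 3 values shown sit.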